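A few compounds are considered here, and "the series" means these few. Any claim that something is new, unique, unknown or untested is made for them only; others in the source may bear on it.

Working notes on the series. Going by the values given here, compound 1 `COc1ccccc1Oc1ccc2c(NCCCNCc3ccco3)ccnc2c1` is one of two compounds so far with a number in an ADME assay for permeability, using PAMPA, with a stated time of 30 min, at pH 7.4; a higher number here means that the compound crosses the layer faster, a lower number that the compound crosses the layer more slowly. Compound 1 gives 317 10^-6 cm/s. Compound 2 `COc1ccc(-c2ccc3c(NCCCNCc4cc(F)ccc4OC)ccnc3c2)cc1` gives 237 10^-6 cm/s in this assay. Compound 1 holds the higher of the two numbers, but the two values lie within the scatter of each other, so no order can be read between them; both are simply high.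

Compound 3 `COc1cccc(Oc2ccc3c(NCCCNCc4ccco4)ccnc3c2)c1` has not yet been measured in this assay. Its difference from compound 1 is a rearrangement of the same atoms: 3-methoxyphenyl in place of 2-methoxyphenyl on an oxygen on an aromatic ring. Cut one bond further out, the change reads 2-methoxyphenoxy to 3-methoxyphenoxy; the rest of the shared core is untouched. Among the compounds with values here, no step between two measured compounds isolates a change of this kind, so nothing measured bears on it directly. Both measured numbers are high and close to each other, which gives no reason to expect a large movement.

The step of a 1.1-fold lower number from compound 1 to compound 3 (0.02 log units; within the scatter) is expected to stay within the scatter, with no fixed direction. Compound 3 is estimated at 300 10^-6 cm/s, with a range from 180 10^-6 cm/s to 480 10^-6 cm/s.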

Compound 3, apparent permeability: 317 10^-6 cm/s
For compound 3 the middle estimate is 1.1-fold (0.02 log units) below the measured one; the range from low to high includes it.
By their numbers in this assay, from the lowest: compounds 2, 1 and 3 (each within the scatter of the next).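

With compound 3 the series has its first step between two measured compounds that differ in one place: in this assay, 3-methoxyphenyl in place of 2-methoxyphenyl on an oxygen on an aromatic ring gives no change at the digits printed from compound 1 to compound 3 (within the scatter). For this pair, then, the rearrangement from 2-methoxyphenoxy to 3-methoxyphenoxy, with the same atoms and the rest of the shared core untouched, leaves the read-out without a change that can be told from the scatter, and the high number of compound 1 is not tied to the 2-methoxyphenyl arrangement. No measurement is at hand that would account for this result.

This is a single step on a single core, and compound 2 differs from compound 3 in more than one place, so it cannot extend the comparison. Open, on these data alone, is whether the number stays this high when the methoxy group on this aromatic ring gives way to a carboxylic acid or a primary amine, and whether a 4-methoxyphenoxy group on the same oxygen would read like 2-methoxyphenoxy and 3-methoxyphenoxy.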